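The source may hold more compounds than are shown below. What is called first, only, known or untested is meant among the compounds shown, and "the series" means these compounds.

In an ADME assay, at pH 5 (on this read-out higher numbers stand for a longer-lived compound and lower numbers for a shorter-lived compound), compound 2 (`COc1cnc(C[S+]([O-])c2nc3cc(OC(F)(F)C(F)F)ccc3[nH]2)cc1OC`) gives 2.9 h and compound 1 (`COc1cnc(C[S+]([O-])c2nc3cc(OC(F)F)ccc3[nH]2)c(C)c1OC`) gives 3.7 h; these two values lie within the scatter of each other. Compound 3 (`COc1cnc(C[S+]([O-])c2nc3cc(OC(F)(F)C(F)F)ccc3[nH]2)c(C)c1OC`) departs from compound 2 by methyl in place of hydrogen on an aromatic carbon. No step beyond the scatter is expected in this assay, in either direction: compound 1 already carries this methyl and gives 3.7 h, within the scatter of compound 2 at 2.9 h. The expected change is small, an estimated 1.0-fold lower number from compound 2 to compound 3 (0.02 log units; within the scatter). Compound 3 is estimated at 2.8 h, with an expected range of 1.6 h to 4.8 h.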

Compound 3, half-life: 6.8 h
Compound 3: middle estimate off by 2.4-fold (0.39 log units), on the low side; the measured number lies above the stated range.
By their numbers in this assay, from the lowest: compounds 2, 1 and 3 (each within the scatter of the next, the first and the last beyond it).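

With the chain shared by compounds 2 and 3, methyl in place of hydrogen on this aromatic carbon gives a 2.3-fold higher number from compound 2 to compound 3 (0.37 log units; beyond the scatter) in this assay and is the only step at this position shown. With the methyl held, difluoromethyl in place of hydrogen on the saturated chain carbon gives a 1.8-fold higher number from compound 1 to compound 3 (0.26 log units; within the scatter) and does not separate from the scatter. No evidence at hand accounts for the methyl step.

On these data alone, whether an ethyl group or a chlorine atom at this carbon would behave like methyl remains open. So does whether the methyl step would recur with other chains on the shared core.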